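This account rests on a few compounds, and the source may have more. Where it says the series, first, only, none or still open, it means among the compounds named here.

Compound 1 `COc1cc2c(cc1OC)CN(/C=N/c1ccc3c(c1)C(OC(C)=O)CCCC3)CC2` and compound 2 `COc1cc2c(cc1OC)CN(/C=N/c1ccc3c(c1)C(OC(C)=O)CC3)CC2` share the same core. In an assay on HEK293 cells for displacement of a labelled ligand from 5-hydroxytryptamine receptor 7 (Homo sapiens) (on this read-out lower numbers stand for stronger inhibition and higher numbers for weaker inhibition), compound 2 gives 1000 nM and compound 1 gives 500 nM; the two numbers lie within the scatter of each other, so no order can be read from them. Compound 3 `CCCCSC1CCc2ccc(/N=C/N3CCc4cc(OC)c(OC)cc4C3)cc21` carries butylsulfanyl in place of acetoxy on a saturated ring carbon. Going by the values given here, no measured pair shows such an exchange, so its effect is untested here; the step expected in this assay is a 1.4-fold lower number from compound 2 to compound 3 (0.15 log units; within the scatter), a change within the scatter rather than a clear move in either direction. For compound 3 the estimated value is 700 nM, with a range of 150 nM to 3000 nM.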

Compound 3, inhibition constant: 36000 nM
The estimate for compound 3 lay 51-fold (1.71 log units) below the measured number, outside the stated range (above it).
By their numbers in this assay, from the lowest: compounds 1 and 2 (each within the scatter of the next); then compound 3.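

In this assay, the group on this saturated ring carbon clearly matters: butylsulfanyl in place of acetoxy gives a 36-fold higher number from compound 2 to compound 3 (1.56 log units; beyond the scatter) and is poorly tolerated here. Going by these compounds alone, compound 1 and compound 2 both carry acetoxy, so only this step tests a change of the group itself. Nothing available explains the loss. From the compounds shown here alone, the step changes the linking atom, the chain and the carbonyl together, so their separate contributions remain open. A hydroxyl, methylsulfanyl or butoxy group on the same carbon would help separate them.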